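The source may report more compounds than this note shows. Statements on the series, on what has been measured and on what is new or still open speak of the compounds shown alone.

Of the compounds shown here, two measured so far in a functional assay on MCF7 cells (Homo sapiens) for inhibition, read by sulforhodamine B assay (on this read-out lower numbers stand for stronger inhibition and higher numbers for weaker inhibition), share one core and differ only in the aromatic ring attached to it. Compound 1 `CCCc1ccc(NC2=CC(=O)c3nc4n(c3C2=O)[C@H]2OC[C@@H](O)[C@H]2OC4)cc1` gives 4660 nM in this assay. Compound 2 `COc1ccccc1NC1=CC(=O)c2c(nc3n2[C@H]2OC[C@@H](O)[C@H]2OC3)C1=O` gives 6580 nM in this assay. Of these two numbers, that of compound 1 is the lower, yet the gap between compound 1 and compound 2 lies within the usual scatter, so neither can be called stronger. Compound 3 `CCOc1ccc(NC2=CC(=O)c3nc4n(c3C2=O)[C@H]2OC[C@@H](O)[C@H]2OC4)cc1` has not been measured yet. It differs from compound 1 in a single place: ethoxy in place of propyl on an aromatic carbon. For the measured compounds named here, no measured pair here shows this exchange, so there is no step to lean on; the two groups match in size and neither adds a ring. For compound 3 the expected step of a 1.1-fold higher number from compound 1 to compound 3 (0.03 log units; within the scatter) in this assay is small, in no clear direction, and not beyond the scatter. The estimated value for compound 3 in this assay is 5000 nM, between 2000 nM and 12500 nM.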

Compound 3, half-maximal inhibitory concentration: 1430 nM
For compound 3 the middle estimate is 3.5-fold (0.54 log units) above the measured one; measured number below the stated range.
By their numbers in this assay, from the lowest: compound 3; then compounds 1 and 2 (each within the scatter of the next).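

Changing this one group on the aromatic ring is not a neutral exchange: in this assay, ethoxy in place of propyl gives a 3.3-fold lower number from compound 1 to compound 3 (0.51 log units; beyond the scatter), a step beyond the scatter. The two groups match in heavy-atom count and neither adds a ring, so at this place, para to a large group, matching in those counts does not guarantee a matching number; the counted difference is that ethoxy brings an oxygen and a hydrogen-bond acceptor that propyl lacks. Nothing available here explains the step, so it cannot be credited to that oxygen.

As far as these compounds go, whether the oxygen or the particular chain matters stays open. A longer butoxy chain or a dimethylamino group at this same place would test how far the step carries over to other groups.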